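Chain extension at the amine-bearing carbon of the dioxolane series

The compounds below may be only part of what the source reports. "The series", "measured", "known", "first", "only" and "open" are said of these compounds alone.

Measured so far in a functional assay (brain) for displacement of a labelled ligand, with Rattus norvegicus as the target; a lower number here means a stronger inhibitor, a higher number a weaker inhibitor:
compound 1 `CCN1CCCC[C@H]1[C@H]1COC(c2ccccc2)(c2ccccc2)O1` gives 6900 nM
compound 2 `CNC[C@H]1COC(c2ccccc2)(c2ccccc2)O1` gives 7300 nM
compound 3 `CN[C@@H](C)[C@H]1COC(c2ccccc2)(c2ccccc2)O1` gives 703 nM

Compound 3 holds the lowest of the three numbers in this assay; its steps to compound 1 and compound 2 are both beyond the scatter, so within this small set it is the strongest inhibitor. Compound 1 and compound 2 sit close together, a 1.1-fold higher number from compound 1 to compound 2 (0.02 log units; within the scatter).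

Compound 4 `CCC[C@H](NC)[C@H]1COC(c2ccccc2)(c2ccccc2)O1` carries the next change on the same carbon: ethyl in place of hydrogen on a saturated chain carbon, two bonds along the chain from an amine nitrogen and a saturated ring carbon. The step that bears on it most directly is a 10-fold lower number from compound 2 to compound 3 (1.02 log units; beyond the scatter), and in the same sense a 9.8-fold lower number from compound 1 to compound 3 (0.99 log units; beyond the scatter); both show that substitution at this carbon moved the number sharply. Nothing measured tells whether a longer chain continues that trend or reverses it, so a smaller move than the earlier one is expected, if any. The expected step is a 1.4-fold lower number from compound 3 to compound 4 (0.15 log units; within the scatter), which is within the scatter. Compound 4 is therefore estimated at 500 nM, with a range from 150 nM to 2000 nM.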

Compound 4, inhibition constant: 7000 nM
Estimate against measurement, compound 4: 14-fold (1.15 log units) below, outside the stated range (above it).
By their numbers in this assay, from the lowest: compound 3; then compounds 1, 4 and 2 (each within the scatter of the next).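

On the saturated chain carbon bound to an amine nitrogen and a saturated ring carbon, the effect of a substituent depends sharply on its length: going from methyl to propyl gives a 10-fold higher number from compound 3 to compound 4 (1.00 log units; beyond the scatter) in this assay and cancels the advantage of compound 3. The steps of a 1.0-fold lower number from compound 2 to compound 4 (0.02 log units; within the scatter) and a 1.0-fold higher number from compound 1 to compound 4 (0.01 log units; within the scatter) are both within the scatter, so among these four compounds only the methyl of compound 3 stands apart, and propyl offers no measurable benefit over hydrogen at this carbon. No data at hand explain this result.

On these data alone, whether an ethyl or a cyclopropyl group on this carbon would behave like methyl or like propyl remains open. As far as these compounds go, it is also open whether a dimethylamino group in place of methylamino would preserve the standing of compound 3.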